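Sulfonyl aryl exchange: from compound 1 to compound 3

The source may report more compounds than this note shows. Statements on the series, on what has been measured and on what is new or still open speak of the compounds shown alone.

Within the data shown here, compound 1 `N#Cc1cccc(S(=O)(=O)c2cnc3cc(F)ccc3c2-c2cccc(F)c2)c1` holds the lower of the two numbers measured so far in an ADME assay on microsomes from liver (Homo sapiens) for metabolic stability, tested at 2.5 uM; a higher number here means faster removal of the compound, a lower number slower removal: compound 1 gives 0.78 mL/min. Among the measured compounds shown here, its nearest neighbour is compound 2 `N#Cc1cccc(S(=O)(=O)c2cnc3cc(F)ccc3c2-c2ccccc2F)c1`, which in this assay gives 1.39 mL/min; the single measured step, a 1.8-fold higher number from compound 1 to compound 2 (0.25 log units; within the scatter), concerns 2-fluorophenyl in place of 3-fluorophenyl on an aromatic carbon and stays within the scatter.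

Compound 3 `COc1ccc(S(=O)(=O)c2cnc3cc(F)ccc3c2-c2cccc(F)c2)cc1` is not yet measured. It differs from compound 1 at another site: 4-methoxyphenyl in place of 3-cyanophenyl on a sulfonyl sulfur. For the measured compounds named here, the measured step does not touch the sulfonyl sulfur, so no measured step bears directly on this change. The only anchor is that the one alteration tried so far in the series left this assay within the scatter, and a step of similar size is taken as the working assumption, with the direction left open.

For compound 3 the number in this assay is expected at 1 mL/min, within 0.4 mL/min to 2.5 mL/min. The expected step of a 1.3-fold higher number from compound 1 to compound 3 (0.11 log units; within the scatter) is thus one within the scatter, wide on either side.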

Compound 3, intrinsic clearance in a liver preparation (reported as CLH), per the amount of preparation that the assay uses: 2.94 mL/min
Compound 3: the middle estimate sits 2.9-fold (0.47 log units) below what was measured; the measured number lies above the stated range.
By their numbers in this assay, from the lowest: compounds 1 and 2 (each within the scatter of the next); then compound 3.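

In this assay, among these compounds, the sulfonyl sulfur is the first site where a change reads beyond the scatter: 4-methoxyphenyl in place of 3-cyanophenyl gives a 3.8-fold higher number from compound 1 to compound 3 (0.58 log units; beyond the scatter), a modest step, whereas the exchange of fluorophenyl groups on an aromatic carbon gives a 1.8-fold higher number from compound 1 to compound 2 (0.25 log units; within the scatter). Both groups on the sulfonyl sulfur are a six-membered aromatic ring of carbon only with no net charge, so the step goes with what the ring carries and where it carries it, not with the type of ring. No measurement shown here gives a reason for this step.

Nitrile and methoxy change together with their ring positions in this one exchange, so the share of each in the step stays open. Also open, as far as these compounds go, is how an unsubstituted phenyl, or an aryl ring carrying an amine or a carboxylic acid, would read on the sulfonyl sulfur, and whether the step from 3-cyanophenyl to 4-methoxyphenyl keeps its size with 2-fluorophenyl on the core.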